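Aryl ether variation on a thiadiazole oxime series

This account rests on a few compounds, and the source may have more. Where it says the series, first, only, none or still open, it means among the compounds named here.

Measured compounds:
- compound 1 `Cc1nnsc1CO/N=C/c1c(C)nn(C)c1Oc1ccccc1Cl`: 42500 nM
- compound 2 `Cc1nnsc1CO/N=C/c1c(C)nn(C)c1Oc1ccc(Br)cc1`: 7190 nM
- compound 3 `Cc1cccc(Oc2c(/C=N/OCc3snnc3C)c(C)nn2C)c1`: 14100 nM

In a functional assay on HCT-116 cells (Homo sapiens) for inhibition, read by MTT assay, with a stated time of 48 h (a lower number here means a stronger inhibitor, a higher number a weaker inhibitor), compound 3 gives 14100 nM. Among the three measured numbers this is the second highest: compound 2 lies nearby with 7190 nM, and the gap a 2.0-fold higher number from compound 2 to compound 3 (0.29 log units; within the scatter) stays within the scatter, while compound 1 sits furthest away with 42500 nM, a difference that a 3.0-fold lower number from compound 1 to compound 3 (0.48 log units; beyond the scatter) places beyond the scatter.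

Compound 4 `Cc1nnsc1CO/N=C/c1c(C)nn(C)c1Oc1cccc(F)c1F` differs from compound 3 only in the aryl ether: 2,3-difluorophenyl in place of 3-methylphenyl on an oxygen on an aromatic ring. Among the measured compounds shown here, two measured steps bear on this position. The step of a 5.9-fold lower number from compound 1 to compound 2 (0.77 log units; beyond the scatter) and the step of a 3.0-fold lower number from compound 1 to compound 3 (0.48 log units; beyond the scatter) both show that moving away from 2-chlorophenyl lowers the number, whereas a 2.0-fold higher number from compound 2 to compound 3 (0.29 log units; within the scatter) shows little separation between 4-bromophenyl and 3-methylphenyl. Compound 4 carries halogens again, one of them in the same position pattern that gave compound 1 the highest number, so a modest rise relative to compound 3 is expected, though it may fall within the scatter.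

Compound 4 is therefore estimated at 22000 nM in this assay, between 8000 nM and 60000 nM, a step of a 1.6-fold higher number from compound 3 to compound 4 (0.19 log units; within the scatter).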

Compound 4, half-maximal inhibitory concentration: 6560 nM
Estimate against measurement, compound 4: 3.4-fold (0.53 log units) above, outside the stated range (below it).
By their numbers in this assay, from the lowest: compounds 4, 2 and 3 (each within the scatter of the next, the first and the last beyond it); then compound 1.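

In this assay, the step of a 2.1-fold lower number from compound 3 to compound 4 (0.33 log units; beyond the scatter) lies beyond the scatter, so exchanging 3-methylphenyl for 2,3-difluorophenyl on this oxygen does change the read-out, while a 1.1-fold lower number from compound 2 to compound 4 (0.04 log units; within the scatter) stays within the scatter and leaves 2,3-difluorophenyl and 4-bromophenyl unseparated. The step of a 6.5-fold lower number from compound 1 to compound 4 (0.81 log units; beyond the scatter) shows that a halogen on the ring does not by itself go with a high number: 2-chlorophenyl and 2,3-difluorophenyl both carry halogen, yet compound 1 remains well apart from compound 4, so the earlier link between halogens and a higher number does not hold across these compounds. Nothing measured on these compounds speaks to the reason for these differences.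

The aryl groups shown carry only halogen or methyl, so how an amine, a methoxy group or a carboxylic acid on the phenyl ring would read in this assay stays open. From the compounds shown here alone, it is also open whether 2-fluorophenyl or 3-fluorophenyl alone would track 2,3-difluorophenyl, and whether the pattern seen here would hold with the shared core changed.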